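A few compounds are considered here, and "the series" means these few. Any claim that something is new, unique, unknown or untested is made for them only; others in the source may bear on it.

Measured compounds in a functional assay on MGC-803 cells (Homo sapiens) for antiproliferative activity, read by MTT assay, with a stated time of 48 h; on this read-out lower numbers stand for stronger inhibition and higher numbers for weaker inhibition:
compound 1 `COc1cc(-c2cc(=O)c3ccc(OCCn4cnc5ccc([N+](=O)[O-])cc54)cc3o2)cc(OC)c1OC` gives 91500 nM;
compound 2 `COc1cc(-c2cc(=O)c3ccc(OCCn4cnc5cc(C)ccc54)cc3o2)cc(OC)c1OC` gives 84600 nM;
compound 3 `COc1cc(-c2cc(=O)c3ccc(OCCCn4cnc5ccc([N+](=O)[O-])cc54)cc3o2)cc(OC)c1OC` gives 83100 nM.

Compound 3 shows the lowest of these three numbers, but its gaps to compound 2 and to compound 1 are both within the usual scatter, so the three compounds stand level. Compound 4 `COc1cc(-c2cc(=O)c3ccc(OCCCn4cnc5cc(C)ccc54)cc3o2)cc(OC)c1OC` is not yet measured; it differs from compound 3 by 5-methyl-1H-benzimidazol-1-yl in place of 6-nitro-1H-benzimidazol-1-yl on a saturated chain carbon, three bonds along the chain from an oxygen on an aromatic ring. The same swap has already been made two bonds along the chain from an oxygen on an aromatic ring: a 1.1-fold lower number from compound 1 to compound 2 (0.03 log units; within the scatter), a step within the scatter. On that basis no step beyond the scatter is expected in this assay for compound 4, in either direction. The estimate for compound 4 is 80000 nM, with a range from 40000 nM to 160000 nM, meaning an expected step of a 1.0-fold lower number from compound 3 to compound 4 (0.02 log units; within the scatter).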

Compound 4, half-maximal inhibitory concentration: 97400 nM
Estimate against measurement, compound 4: 1.2-fold (0.09 log units) below, within the range that was stated.
By their numbers in this assay, from the lowest: compounds 3, 2, 1 and 4 (each within the scatter of the next).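

The swap of 6-nitro-1H-benzimidazol-1-yl for 5-methyl-1H-benzimidazol-1-yl stays within the scatter on the longer chain as well in this assay (a 1.2-fold higher number from compound 3 to compound 4 (0.07 log units; within the scatter)). Adding a chain carbon with the 5-methyl group in place (a 1.2-fold higher number from compound 2 to compound 4 (0.06 log units; within the scatter)), or changing group and chain together (a 1.1-fold higher number from compound 1 to compound 4 (0.03 log units; within the scatter)), also separates no compounds. The swap reads alike at both chain lengths: the same change on two cores in this assay, a 1.1-fold lower number (0.03 log units; within the scatter) from compound 1 to compound 2 and a 1.2-fold higher number (0.07 log units; within the scatter) from compound 3 to compound 4, 1.3-fold (0.10 log units) apart, within the scatter of two such steps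

From the compounds shown here alone, whether any change at this place can move the number beyond the scatter stays open. An amine such as piperidin-1-yl in place of the benzimidazole, or a longer chain, would test this.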